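The compounds below may be only part of what the source reports. "The series", "measured", "known", "first", "only" and "open" are said of these compounds alone.

Measured so far in a functional assay on A549 cells (Homo sapiens) for antiproliferative activity, read by MTT assay, with a stated time of 72 h; on this read-out higher numbers stand for weaker inhibition and lower numbers for stronger inhibition:

Compound 1, `CN(C(=O)c1ccc(F)cc1)c1ccc2[nH]c(-c3n[nH]c4ccccc34)cc2n1`: 9650 nM
Compound 2, `COc1ccc(C(=O)N(C)c2ccc3[nH]c(-c4n[nH]c5ccccc45)cc3n2)cc1`: 14600 nM

Compound 2 stands at the higher of the two numbers, with compound 1 nearest; the step of a 1.5-fold higher number from compound 1 to compound 2 (0.18 log units; within the scatter) lies within the scatter. Compound 3 is `CN(C(=O)c1ccc([N+](=O)[O-])cc1)c1ccc2[nH]c(-c3n[nH]c4ccccc34)cc2n1`. The change from compound 2 to compound 3 is nitro in place of methoxy on an aromatic carbon, on an aromatic carbon of a six-membered aromatic ring of carbon only, para to a large group. Going by the values given here, no measured step involves a nitro group, so the only step that bears on the place is a 1.5-fold higher number from compound 1 to compound 2 (0.18 log units; within the scatter), where exchanging one small para substituent for another moved the number only within the scatter. On that basis a change of similar scale is expected here, with no clear direction. The expected step is a 1.3-fold lower number from compound 2 to compound 3 (0.12 log units; within the scatter), within the scatter. For compound 3 the estimate in this assay is 11000 nM, with a range from 4000 nM to 30000 nM.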

Compound 3, half-maximal inhibitory concentration: 34500 nM
Compound 3: middle estimate off by 3.1-fold (0.50 log units), on the low side, and the stated range ends below it.
By their numbers in this assay, from the lowest: compounds 1 and 2 (each within the scatter of the next); then compound 3.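

In this assay the place para to a large group now proves able to move the number beyond the scatter: the change from 4-methoxyphenyl to 4-nitrophenyl gives a 2.4-fold higher number from compound 2 to compound 3 (0.37 log units; beyond the scatter) and, starting from the fluoro group, nitro gives a 3.6-fold higher number from compound 1 to compound 3 (0.55 log units; beyond the scatter) in the same direction. The earlier exchange of fluoro for methoxy had stayed within the scatter, so this position does respond to what it carries, though both new steps are modest, and among these three compounds nitro goes with the weakest inhibition. Nothing available here explains the shift.

Going by these compounds, whether an amine or a carboxylic acid at this place would sit with nitro or with fluoro and methoxy remains open. So does whether a hydrogen at this place would give stronger inhibition than any of the three groups.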